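The source may report more compounds than this note shows. Statements on the series, on what has been measured and on what is new or still open speak of the compounds shown alone.

compound 1 `O=C(CCCCC(S)CCS)NO` gives 10.6%
compound 2 `O=C(CCCCC(S)CCS)Nc1ccccc1` gives 11.6%
compound 3 `O=C(CCCCC(S)CCS)Nc1cccc(Cl)c1` gives "not active" (no number reported)
compound 4 `O=C(CCCCC(S)CCS)Nc1ccc(OC(F)(F)F)cc1` is not yet measured

Within the data shown here, in a functional assay on KB cells (Homo sapiens) for inhibition, read by MTT assay, with a stated time of 24 h, tested at 1 ug/mL (on this read-out higher numbers stand for more inhibition of growth at the one concentration tested and lower numbers for less inhibition of growth), compound 2 gives 11.6% and stands within the scatter of compound 1, the only other number. Compound 3 has no number and reads "not active" (no number reported) in the same test.

The change to compound 4 is trifluoromethoxy in place of hydrogen on an aromatic carbon with trifluoromethoxy in place of hydrogen on an aromatic carbon, para to a large group. Among the measured compounds shown here, the only measured step, a number 1 percentage points higher from compound 1 to compound 2 (within the scatter), lies at the amide-type nitrogen and not on the aromatic ring, so it bears on this change only indirectly. Compound 3 supplies no step size. For the measured compounds named here, no measured step goes beyond the scatter, so no step beyond it is expected in this assay and no direction can be given. The expected step is a number 0.4 percentage points higher from compound 2 to compound 4 (within the scatter) and it stays within the scatter. A reading without a number, as for compound 3, remains possible.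

For compound 4 the estimated value is 12% with 3% to 30% as the expected range.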

Compound 4, percent growth inhibition at one concentration: 6%
For compound 4 the middle estimate is 6 percentage points above the measured one; low and high end bracket the measured number.
By their numbers in this assay, from the lowest: compounds 4, 1 and 2 (each within the scatter of the next).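

In this assay, among these compounds, trifluoromethoxy in place of hydrogen on an aromatic carbon, para to a large group, gives a number 5.6 percentage points lower from compound 2 to compound 4 (within the scatter) and is the first numeric step read on the aromatic ring itself. Among the compounds shown here, this place therefore carries a substituent without any step beyond the scatter, and the single step at the amide-type nitrogen now has a companion of the same standing: neither separates its two compounds at the one concentration tested. No measured evidence bears on this result.

Going by these compounds, whether an amine or a carboxylic acid at this same place would move the number beyond the scatter remains open. Also open, on these data alone, is whether a longer chain in place of the chain carrying the two thiol groups would give any step beyond the scatter in this assay and so show a real dependence on structure.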